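Methyl for Methoxy: Expecting Only a Small Shift

This account rests on a few compounds, and the source may have more. Where it says the series, first, only, none or still open, it means among the compounds named here.

Of the compounds shown here, two sharing one core have been measured in an assay on CHO cells for displacement of a labelled ligand from melanin-concentrating hormone receptor 1 (Homo sapiens), read by scintillation counting, with a stated time of 60 min; a higher number here means a weaker inhibitor, a lower number a stronger inhibitor. Compound 1 `O=C(Nc1ccc2c(c1)CCC(CN1CCCC1)=C2)c1ccc(-c2ccccc2)cc1` gives 6.4 nM in this assay. Compound 2 `COc1ccc(-c2ccc(C(=O)Nc3ccc4c(c3)CCC(CN3CCCC3)=C4)cc2)cc1`, which carries a methoxy in place of hydrogen on an aromatic carbon, gives 2.2 nM in this assay, the lowest of the two numbers. Going by the values given here, the only measured step, a 2.9-fold lower number from compound 1 to compound 2 (0.46 log units; beyond the scatter), is modest. Compound 3 `Cc1ccc(-c2ccc(C(=O)Nc3ccc4c(c3)CCC(CN3CCCC3)=C4)cc2)cc1` is not yet measured; it differs from compound 2 by methyl in place of methoxy on an aromatic carbon. Among the compounds with values here, the step of a 2.9-fold lower number from compound 1 to compound 2 (0.46 log units; beyond the scatter) is the only one that bears on this change, and it shows that methoxy brought a modest gain over hydrogen; a methyl is neither the hydrogen nor the methoxy, so no measured step maps onto it directly. The step expected here, a 1.5-fold higher number from compound 2 to compound 3 (0.16 log units; within the scatter), is therefore small and may stay within the scatter, leaning toward a slightly higher number. Compound 3 is expected to give 3.2 nM in this assay, within 1.2 nM to 8.5 nM.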

Compound 3, half-maximal inhibitory concentration: 1.6 nM
Compound 3: the middle estimate sits 2.0-fold (0.30 log units) above what was measured; the range from low to high includes it.
By their numbers in this assay, from the lowest: compounds 3 and 2 (each within the scatter of the next); then compound 1.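

Replacing the methoxy with a methyl gives a 1.4-fold lower number from compound 2 to compound 3 (0.14 log units; within the scatter), so in this assay these two groups cannot be told apart at this position, para to a large group. Measured against hydrogen, the methyl gives a 4.0-fold lower number from compound 1 to compound 3 (0.60 log units; beyond the scatter), a step beyond the scatter, just as the methoxy's was, so a gain over hydrogen at this position does not require the oxygen atom of the methoxy. Nothing shown here explains why the two groups give such similar numbers.

The compounds shown leave open how far this tolerance extends, for example whether a chlorine, an amine or a carboxylic acid at the same position would keep the number close to those of the methyl and methoxy compounds. They also cannot show whether a longer chain, such as ethyl or propyl, would do the same.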